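Naphthalen-2-yl to 4-Fluorophenyl on an Amide Nitrogen

The source may report more compounds than this note shows. Statements on the series, on what has been measured and on what is new or still open speak of the compounds shown alone.

Measured compounds:
compound 1 `O=C(COc1c(-c2ccccc2)oc2ccccc2c1=O)Nc1ccc2ccccc2c1`: 6500 nM
compound 2 `O=C(COc1ccc2oc(-c3ccccc3)cc(=O)c2c1)Nc1ccc2ccccc2c1`: 6710 nM
compound 3 `O=C(COc1c(-c2ccccc2)oc2ccccc2c1=O)Nc1ccc(F)cc1`: a limit

In a functional assay on NCI-H661 cells (Homo sapiens) for antiproliferative activity, read by MTT assay, with a stated time of 72 h (on this read-out higher numbers stand for weaker inhibition of growth and lower numbers for stronger inhibition of growth), compound 1 gives 6500 nM and compound 2 gives 6710 nM; the two numbers lie within the scatter of each other. Compound 1 and compound 2 share the same atoms joined differently, and the difference between their two cores is not broken down here. Compound 3 reaches only the limit of this assay, > 10000 nM. The change from compound 1 to compound 3, (4-fluorophenyl in place of naphthalen-2-yl on an amide-type nitrogen), gave an at least 1.5-fold higher number from compound 1 to compound 3 (0.18 log units; that floor lies within the scatter). That step is known only as a floor because the limit of > 10000 nM in this assay, at which 1 of the 3 values shown sits, sets what compound 3 can show.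

Compound 4 `O=C(COc1ccc2oc(-c3ccccc3)cc(=O)c2c1)Nc1ccc(F)cc1` carries the same change on the core of compound 2: 4-fluorophenyl in place of naphthalen-2-yl on an amide-type nitrogen. The place is the same in both cases, so this is the same change. Compound 4 is expected to move by a 2.2-fold higher number from compound 2 to compound 4 (0.35 log units; beyond the scatter) from compound 2 in this assay, resting on the floor seen from compound 1 to compound 3. Compound 4 is estimated at 15000 nM, between 7000 nM and 40000 nM, with a real chance that only a limit is reported.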

Compound 4, concentration for 50% growth inhibition: 1470 nM
The estimate for compound 4 lay 10-fold (1.01 log units) above the measured number; measured number below the stated range.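

On the core of compound 2, in this assay, 4-fluorophenyl in place of naphthalen-2-yl on an amide-type nitrogen gave a 4.6-fold lower number from compound 2 to compound 4 (0.66 log units; beyond the scatter). The same change did not carry over unchanged from the core of compound 1, so in this series its outcome cannot be transferred from one core to the other: the same change on two cores in this assay, an at least 1.5-fold higher number (0.18 log units; that floor lies within the scatter) from compound 1 to compound 3 and a 4.6-fold lower number (0.66 log units; beyond the scatter) from compound 2 to compound 4, at least 7.0-fold (0.84 log units) apart, beyond the scatter of two such steps. Compound 3 stands at a limit, so the size of the step on its core stays unknown, and two pairs do not show why the cores part: the limit of > 10000 nM in this assay, at which 1 of the 4 values shown sits.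

The compounds shown leave open whether the cores would also part with other groups on the amide nitrogen, such as an unsubstituted phenyl, a 4-chlorophenyl or a cyclohexyl. On these data alone, it also remains open how either core would respond to a longer chain between the ring oxygen and the amide carbonyl, or to a pyridine ring in place of the phenyl on the core.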